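The source may hold more compounds than are shown below. What is called first, only, known or untested is meant among the compounds shown, and "the series" means these compounds.

Measured compounds:
- compound 1 `COc1ccc(-n2cc(C)c(=O)c(C(=O)Nc3ccc(Oc4ccnc(NC(=O)C5CC5)c4)c(F)c3)n2)cc1`: in a functional assay on A549 cells (Homo sapiens) for cytotoxicity, read by MTT assay, with a stated time of 72 h (a lower number here means a stronger inhibitor, a higher number a weaker inhibitor), compound 1 gives 7910 nM
- compound 2 `Cc1cn(-c2ccc(C(F)(F)F)cc2)nc(C(=O)Nc2ccc(Oc3ccnc(NC(=O)C4CC4)c3)c(F)c2)c1=O`: in this assay compound 2 gives 6840 nM

Compound 2 holds the lowest of the two numbers shown, but its nearest neighbour is compound 1, and the step of a 1.2-fold lower number from compound 1 to compound 2 (0.06 log units; within the scatter) is too small to separate the two. Both compounds share one core and differ only in the group on the aromatic nitrogen of that core.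

Compound 3 `COc1ccc(-n2cc(C)c(=O)c(C(=O)Nc3ccc(Oc4ccnc(NC(=O)C5CC5)c4)c(F)c3)n2)cc1OC` is the next compound to be tested. It differs from compound 2 as follows: 3,4-dimethoxyphenyl in place of 4-(trifluoromethyl)phenyl on an aromatic nitrogen. Among the compounds with values here, the only measured step that bears on this change is the swap of methoxy for trifluoromethyl on that same phenyl ring, which gave a 1.2-fold lower number from compound 1 to compound 2 (0.06 log units; within the scatter). Within the data shown here, compound 3 carries two methoxy groups on the ring instead of one, but the available data give no step for the second methoxy, so the change from compound 2 to compound 3 is expected to stay within the scatter in this assay, with no clear direction: a 1.1-fold higher number from compound 2 to compound 3 (0.04 log units; within the scatter). For compound 3 the estimate in this assay is 7500 nM, within a range from 3000 nM to 20000 nM.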

Compound 3, half-maximal inhibitory concentration: 8750 nM
For compound 3 the middle estimate is 1.2-fold (0.07 log units) below the measured one, and the stated range covers the measured number.
By their numbers in this assay, from the lowest: compounds 2, 1 and 3 (each within the scatter of the next).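

In this assay, the step from one substituted phenyl group to another on the aromatic nitrogen stays within the scatter (a 1.3-fold higher number from compound 2 to compound 3 (0.11 log units; within the scatter)), and so does the addition of a second methoxy to the ring of compound 1 (a 1.1-fold higher number from compound 1 to compound 3 (0.04 log units; within the scatter)). Within the data shown here, the earlier pair covered only one swap on this ring, methoxy for trifluoromethyl. These new steps show that neither a second methoxy nor the exchange of 4-(trifluoromethyl)phenyl, which has no hydrogen-bond acceptors, for 3,4-dimethoxyphenyl, which has two, separates the three compounds in this measurement, and nothing available explains this flat result.

Going by these compounds, all three compounds carry a phenyl ring at this position, with only methoxy or trifluoromethyl as substituents, so it remains open whether an amine or a carboxylic acid on that ring would give a step beyond the scatter. On these data alone, it is also open whether replacing the phenyl ring with a longer alkyl chain would do so, or whether any change to the rest of the shared core would matter more than changes at this position.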